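The source may hold more compounds than are shown below. What is called first, only, known or untested is meant among the compounds shown, and "the series" means these compounds.

Working notes on the series in a toxicity assay on the whole organism (strain Icem-CET (SPF Caw)) for cytotoxicity, with Mus musculus as the target; a higher number here means that more compound is needed for the effect, a lower number that less compound is needed.

Compound 1 `C#CCNC(=O)/C(C)=C(\C)c1ccc(OC)cc1` gives 400 mg/kg in this assay. Compound 3 `C=CCNC(=O)/C(C)=C(\C)c1ccc(OC)cc1` gives 300 mg/kg, and compound 2 `C/C(C(=O)NC1CC1)=C(/C)c1ccc(F)cc1` gives 200 mg/kg. Within the data shown here, the number for compound 1 is nominally the largest of the three, but none of the three separates from another beyond the scatter: the single one-place step, a 1.3-fold lower number from compound 1 to compound 3 (0.12 log units; within the scatter), stays within it, and compound 2 differs from compound 1 in more than one place, so its number can only be set next to that of compound 1 without being read as a step.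

Compound 4 `C#CCNC(=O)/C(C)=C(\C)c1ccc(C)cc1` differs from compound 1 by methyl in place of methoxy on an aromatic carbon. Among the measured compounds shown here, no measured step touches the aromatic ring: the only step in hand, a 1.3-fold lower number from compound 1 to compound 3 (0.12 log units; within the scatter), alters the chain on the amide nitrogen, and compound 2 carries both a different chain and a different ring substituent. The pattern so far, across compounds 1, 2 and 3, is one of numbers that do not move beyond the scatter, and the change to compound 4 is small in count.

The step of no change at the digits printed from compound 1 to compound 4 (within the scatter) is therefore expected to stay within the scatter. For compound 4 the estimate in this assay is 400 mg/kg, with a range from 200 mg/kg to 800 mg/kg.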

Compound 4, dose for half-maximal effect: 200 mg/kg
Estimate against measurement, compound 4: 2.0-fold (0.30 log units) above, and the stated range covers the measured number.
By their numbers in this assay, from the lowest: compounds 2, 4, 3 and 1 (each within the scatter of the next).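

In this assay, among these compounds, a 2.0-fold lower number from compound 1 to compound 4 (0.30 log units; within the scatter) gives the first reading at the aromatic carbon, para to a large group, since the only earlier step lay on the chain at the amide nitrogen. Replacing methoxy with methyl removes one hydrogen-bond acceptor and one heavy atom, yet this step stays within the scatter, so on these two compounds the position shows no separable response to this exchange, and the ring change joins the chain change from ethynyl to vinyl as a step that does not clear the scatter. No available evidence bears on this result, so it remains a bare comparison of two numbers.

The compounds shown leave open whether this aromatic carbon responds to any group more different from methoxy and methyl, such as an amine or a carboxylic acid, since only this one exchange can be read there. Also open, on these data alone, is whether methyl on the ring and vinyl on the chain behave the same way when combined on the shared core, and compound 2 cannot settle either question, as it differs from the others in more than one place.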